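A few compounds are considered here, and "the series" means these few. Any claim that something is new, unique, unknown or untested is made for them only; others in the source may bear on it.

Measured so far in a functional assay on A549 cells (Homo sapiens) for antiproliferative activity, read by sulforhodamine B assay, with a stated time of 48 h; a lower number here means a stronger inhibitor, a higher number a weaker inhibitor:
compound 1 `COc1cc(OC)c2sc(-c3ccc(N/C=C\C(=O)c4ccc(OC)c(O)c4)cc3)nc2c1` gives 10600 nM
compound 2 `COc1cc(OC)c2sc(-c3ccc(N/C=C\C(=O)c4cc(OC)c(OC)c(OC)c4Br)c(C)c3)nc2c1` gives 14000 nM
compound 3 `COc1ccc(C(=O)/C=C\Nc2ccc(-c3nc4cc(OC)c(OC)c(OC)c4s3)cc2)cc1O` gives 23000 nM

Compound 2 lies within the scatter of both compound 1 and compound 3, although those two are separated by a step beyond the scatter. The next compound is compound 4 `COc1cc(OC)c2sc(-c3ccc(N/C=C\C(=O)c4cc(OC)c(OC)c(OC)c4)c(C)c3)nc2c1`, not yet measured. Its difference from compound 2 is hydrogen in place of bromo on an aromatic carbon and amounts to hydrogen in place of bromo on an aromatic carbon, ortho to a large group.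

Among the measured compounds shown here, the only measured step at a single place, a 2.2-fold higher number from compound 1 to compound 3 (0.34 log units; beyond the scatter), is modest. That step is methoxy in place of hydrogen on an aromatic carbon of the shared core, so it is a different change at a different site and serves only as a loose guide to size. For the measured compounds named here, no measured step removes a bromo, which leaves the direction open. In this assay no step beyond the scatter is therefore expected in either direction. Compound 2 with 14000 nM as its value is the anchor for the expectation. The expected change is a 1.3-fold lower number from compound 2 to compound 4 (0.10 log units; within the scatter) and is estimated to stay within the scatter. For compound 4 the estimated value is 11000 nM with an expected range from 3500 nM to 30000 nM here.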

Compound 4, half-maximal inhibitory concentration: 14400 nM
Compound 4: the middle estimate sits 1.3-fold (0.12 log units) below what was measured, within the range that was stated.
By their numbers in this assay, from the lowest: compounds 1, 2, 4 and 3 (each within the scatter of the next, the first and the last beyond it).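

In this assay, among the compounds shown here, replacing bromo with hydrogen on this aromatic carbon gives a 1.0-fold higher number from compound 2 to compound 4 (0.01 log units; within the scatter), the first measured step at this position. Bromo, ortho to a large group, can therefore give way to hydrogen with the two values staying within the scatter of each other, so within this pair the bromo makes no measurable difference to the read-out, and the position tolerates the loss of that one heavy atom. No measurement shown accounts for this result, and it gives no reason for the outcome.

At this aromatic carbon, the compounds shown hold only bromo and hydrogen, so it remains open whether an amine, a carboxylic acid or a longer chain such as an ethoxy group would also stay within the scatter of compound 4. From the compounds shown here alone, the reading also rests on a single pair carrying the same methyl-bearing aryl ring and the same methoxy groups, so it remains open whether the same exchange would read alike on the core of compound 1, which lacks that methyl group.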